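A few compounds are considered here, and "the series" means these few. Any claim that something is new, unique, unknown or untested is made for them only; others in the source may bear on it.

The measured compounds:
compound 1 `C=CC(=O)Nc1cccc(Nc2ncnc(Nc3ccc(C(=O)Nc4ccc(C)cn4)cc3)n2)c1`, > 100000 nM;
compound 2 `C=CC(=O)Nc1cccc(Nc2ncnc(Nc3ccc(-c4ccc(OC)nc4)cc3)n2)c1`, "not determined" (no result reported);
compound 3 `C=CC(=O)Nc1cc(Nc2ncnc(Nc3ccc(C(=O)N4CCCCC4)cc3)n2)ccc1C`, 48500 nM.

In a functional assay on Ramos cells (Homo sapiens) for antiproliferative activity, read by CCK-8 assay, with a stated time of 24 h (on this read-out lower numbers stand for stronger inhibition and higher numbers for weaker inhibition), compound 1 gives > 100000 nM, which is a limit of the assay and not a number. Compound 3 gives 48500 nM in this assay, a weak result in its own right. Compound 2 stands without a number of its own, as no result was reported for it, and among the three entries one further value sits at the limit described by the limit of > 100000 nM in this assay, at which 1 of the 3 values shown sits. Compound 4 `C=CC(=O)Nc1cccc(Nc2ncnc(Nc3ccc(Oc4ccc(OC)cc4)cc3)n2)c1` differs from compound 2 in one place: 4-methoxyphenoxy in place of 6-methoxypyridin-3-yl on an aromatic carbon. Among the compounds with values here, compound 2 has no number, so no measured step leads to compound 4, and the only bearings come from the weak values of compound 1 and compound 3 on the shared core. With nothing in the shown values to separate compound 2 from compound 4, the step between them in this assay is expected to be none beyond the scatter, in either direction. Compound 4 is therefore expected to remain in the same weak region, with an estimated 60000 nM in this assay and a range from 10000 nM to 300000 nM.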

Compound 4, half-maximal inhibitory concentration: > 100000 nM
Compound 4: only a limit was reported; the forecaster's own chance of this, stated with the estimate: 40%; middle value at least 1.6-fold (0.22 log units) away from the limit.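

In this assay compound 4 gives > 100000 nM as a limit of the assay and not a number. No new step can be read from compound 1 to compound 4, since both stand at one limit: the limit of > 100000 nM in this assay, at which 2 of the 4 values shown sit. In this assay the compounds shown leave open how far compound 1 and compound 4 lie apart, and whether compound 2 and compound 4 differ at all.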